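Methyl for chloro on the aryl sulfone of compound 1

A few compounds are considered here, and "the series" means these few. Any claim that something is new, unique, unknown or untested is made for them only; others in the source may bear on it.

Measured so far:
compound 1 `O=S(=O)(c1ccc(Cl)cc1)c1n[nH]c2cccc(N3CCNCC3)c12`: 125 nM
compound 2 `CN1CCN(c2ccc3[nH]nc(S(=O)(=O)c4ccc(Cl)cc4)c3c2)CC1`: 8.1 nM

In an assay on HeLa cells for displacement of a labelled ligand from 5-hydroxytryptamine receptor 6 (Homo sapiens) (a higher number here means a weaker inhibitor, a lower number a stronger inhibitor), compound 1 gives 125 nM, the higher of the two numbers recorded; compound 2 gives 8.1 nM, and the gap between the two lies beyond the usual scatter. Compound 2 differs from compound 1 in more than one place, so the two values show only where each stands, not what any single change contributes.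

Compound 3 `Cc1ccc(S(=O)(=O)c2n[nH]c3cccc(N4CCNCC4)c23)cc1` has not yet been measured. It differs from compound 1 in one place, described as methyl in place of chloro on an aromatic carbon. For the measured compounds named here, nothing measured separates a chloro from a methyl at that position, so there is no step to lean on. A change of this kind, on a group remote from the part carrying the piperazine, is expected to move the number little; an estimate is placed close to compound 1, leaning slightly toward a higher number. The expected step is a 1.3-fold higher number from compound 1 to compound 3 (0.11 log units; within the scatter). Compound 3 is therefore estimated at 160 nM, with a range from 60 nM to 420 nM.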

Compound 3, inhibition constant: 134 nM
Compound 3: the middle estimate sits 1.2-fold (0.08 log units) above what was measured; the range from low to high includes it.
By their numbers in this assay, from the lowest: compound 2; then compounds 1 and 3 (each within the scatter of the next).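

In this assay, for the compounds shown here, the change from 4-chlorophenyl to 4-methylphenyl on the shared core gives a 1.1-fold higher number from compound 1 to compound 3 (0.03 log units; within the scatter) and provides the first reading at this position. At this place on the sulfone aryl ring, chloro and methyl cannot be told apart in this series, so the chlorine of compound 1 can give way to a methyl without a step beyond the scatter. No measurement at hand accounts for this result.

As far as these compounds go, whether this position accepts other groups stays open: an amine, a carboxylic acid, a methoxy or a longer chain such as propyl could read quite differently from chloro and methyl. Also open, from the compounds shown here alone, is whether the same change would read alike on compound 2 , which gives 8.1 nM and differs from compound 1 in more than one place.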